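The source may hold more compounds than are shown below. What is called first, only, known or untested is meant among the compounds shown, and "the series" means these compounds.

Three compounds have been measured so far in an in vitro assay on HEK385-7 cells for displacement of a labelled ligand from prostaglandin D2 receptor 2 (Homo sapiens); a lower number here means a stronger inhibitor, a higher number a weaker inhibitor:

Compound 1, `O=C(O)Cc1sc(C(c2ccccc2)c2ccccc2)nc1-c1ccc(C(F)(F)F)cc1`, gives 1100 nM.
Compound 2, `O=C(O)Cc1sc(C(c2ccccc2)c2ccc(O)cc2)nc1-c1ccc(F)cc1`, gives 3.4 nM.
Compound 3, `O=C(O)Cc1sc(C(c2ccc(F)cc2)c2ccc(F)cc2)nc1-c1cc(F)cc(F)c1`, gives 35 nM.

Among these three numbers compound 3 stands second highest. Its nearest neighbour is compound 2, whose number is lower by a gap beyond the usual scatter, so compound 2 is the stronger inhibitor of the two. The furthest is compound 1, whose number is higher again by a gap well beyond the scatter, so compound 3 is clearly the stronger of that pair.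

Compound 4, `O=C(O)Cc1sc(C(c2ccc(F)cc2)c2ccc(F)cc2)nc1-c1ccnc(O)c1`, has not yet been measured. It differs from compound 3 in one place: 2-hydroxypyridin-4-yl in place of 3,5-difluorophenyl on an aromatic carbon. Going by the values given here, no measured pair in this set differs by only this change, so there is no directly comparable step to lean on. In this assay the step from compound 3 to compound 4 is expected to be a modest weakening, a 1.7-fold higher number from compound 3 to compound 4 (0.23 log units; within the scatter), though it may well fall within the scatter. Compound 4 is therefore estimated at about 60 nM, with a plausible range from 15 nM to 250 nM.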

Compound 4, half-maximal inhibitory concentration: 68 nM
Estimate against measurement, compound 4: 1.1-fold (0.05 log units) below, and the stated range covers the measured number.
By their numbers in this assay, from the lowest: compound 2; then compounds 3 and 4 (each within the scatter of the next); then compound 1.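

Going by these compounds alone, this is the first step in the set that changes only the aromatic group on the ring carbon next to the ring nitrogen, with the rest of the molecule held fixed. In this assay, putting 2-hydroxypyridin-4-yl in place of 3,5-difluorophenyl gives a 1.9-fold higher number from compound 3 to compound 4 (0.29 log units; within the scatter), so the two compounds cannot be told apart by this measurement. The position therefore accepts a ring with a hetero atom, one hydrogen-bond donor and two hydrogen-bond acceptors in place of a carbon-only ring with two fluorines and none of these, without a change beyond the scatter, and nothing measured here explains why that is so.

The step cannot show which part of the new group matters, and that would need close relatives at this position, such as 2-methoxypyridin-4-yl, 2-aminopyridin-4-yl or an unsubstituted pyridin-4-yl. It also leaves open whether the same exchange would behave alike if the two 4-fluorophenyl groups on the large group were replaced, for example by a pair of plain phenyl rings.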